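Swapping a chlorobenzyl for a hydroxyphenyl on the shared core

A few compounds are considered here, and "the series" means these few. Any claim that something is new, unique, unknown or untested is made for them only; others in the source may bear on it.

Of the compounds shown here, three built on one shared core have been tested in a functional assay on K562 cells (Homo sapiens) for inhibition, read by fluorescence, with a stated time of 72 h; a lower number here means a stronger inhibitor of growth, a higher number a weaker inhibitor of growth. Compound 1 `CC(C)CCn1cnc2c(NCc3cccc(Cl)c3)nc(N[C@H]3CC[C@H](N)CC3)nc21` gives 3100 nM in this assay. Compound 2 `CC(C)=CCn1cnc2c(Nc3cccc(Cl)c3)nc(N[C@H]3CC[C@H](N)CC3)nc21` gives 3500 nM, and compound 3 `CCCCn1cnc2c(Nc3cc(OC)cc(OC)c3)nc(N[C@H]3CC[C@H](N)CC3)nc21` gives 2400 nM. Compound 1 has the second highest of these three numbers; its nearest neighbour is compound 2, and its furthest is compound 3, yet both gaps fall within the usual scatter of repeated measurements, so the three compounds cannot be ranked against each other on these numbers.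

Compound 4 `CC(C)CCn1cnc2c(Nc3ccc(O)cc3)nc(N[C@H]3CC[C@H](N)CC3)nc21` has not yet been measured. It differs from compound 1 in one place: 4-hydroxyphenyl in place of 3-chlorobenzyl on a nitrogen on an aromatic ring. Going by the values given here, no measured pair in this set isolates that single change, so the size of the step has to be judged from how tightly the three measured values cluster. Since compound 1, compound 2 and compound 3 all sit close together in this assay, the expectation is that the step of a 1.2-fold lower number from compound 1 to compound 4 (0.09 log units; within the scatter) will be small, with no direction beyond the scatter. Compound 4 is therefore estimated to give about 2500 nM in this assay, with a plausible range from 900 nM to 7000 nM.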

Compound 4, concentration for 50% growth inhibition: 4600 nM
Compound 4: middle estimate off by 1.8-fold (0.26 log units), on the low side, and the stated range covers the measured number.
By their numbers in this assay, from the lowest: compounds 3, 1, 2 and 4 (each within the scatter of the next).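

In this assay, going by these compounds alone, putting 4-hydroxyphenyl in place of 3-chlorobenzyl on a nitrogen on an aromatic ring gives a 1.5-fold higher number from compound 1 to compound 4 (0.17 log units; within the scatter), the first step in this set that isolates a single change on the shared core. The swap is not a subtle one: the leaving group has 0 hydrogen-bond donors and 0 hydrogen-bond acceptors, while the entering group has 1 of each, and chlorine gives way to oxygen, yet compound 1 and compound 4 cannot be told apart on these numbers. No available evidence explains this result, so it records only the size of the step, with no cause attached.

Because this one swap alters the group at several points at once, it leaves open what each part contributes, and a 4-hydroxybenzyl or a 3-hydroxyphenyl group on the same nitrogen would help to separate them. It also leaves open whether a group of another kind at this position, such as a carboxylic acid or an amine on the aromatic ring, would move the number beyond the scatter.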